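Swapping the Amide Group of Compound 2

The source may hold more compounds than are shown below. What is called first, only, known or untested is meant among the compounds shown, and "the series" means these compounds.

Measured in a functional assay on MDA-MB-231 cells (Homo sapiens) for cytotoxicity, read by MTT assay, with a stated time of 72 h; on this read-out higher numbers stand for weaker inhibition and lower numbers for stronger inhibition:
Compound 1 `O=C(CN1CCN(c2nnc(Cc3ccccc3)c3ccccc23)CC1)Nc1c(F)cccc1F` gives 5490 nM
Compound 2 `O=C(CN1CCN(c2nnc(Cc3ccncc3)c3ccccc23)CC1)Nc1cccc(Br)c1` gives 1.7 nM
Compound 3 `O=C(CN1CCN(c2nnc(Cc3ccccc3)c3ccccc23)CC1)Nc1ccc(F)c(F)c1` gives 2750 nM

Compound 2 has the lowest of these three numbers, and compounds 1 and 3 both lie far above it, well beyond the scatter of repeated measurements. Lower numbers mean stronger inhibition here, which makes compound 2 the most potent of the three.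

The unmeasured compound 4 `Cc1ccc(F)cc1NC(=O)CN1CCN(c2nnc(Cc3ccncc3)c3ccccc23)CC1` differs from compound 2 in one group: 5-fluoro-2-methylphenyl in place of 3-bromophenyl on an amide-type nitrogen. In short, 5-fluoro-2-methylphenyl stands in place of 3-bromophenyl on an amide-type nitrogen.

Among the measured compounds shown here, only one measured step changes the group at this place: a 2.0-fold lower number from compound 1 to compound 3 (0.30 log units; within the scatter). That step hints that a swap here can leave the number nearly unchanged. It is weak guidance, however, as it comes from a single pair that also differs from compound 2 elsewhere in the structure. For the measured compounds named here, no measured pair shows this exact swap.

A modest rise is expected rather than a fall, since compound 2 sits at 1.7 nM at the bottom of the measured numbers. The expected change is an 8.8-fold higher number from compound 2 to compound 4 (0.95 log units; beyond the scatter), an estimate with wide uncertainty. For compound 4 the estimated value is 15 nM with an expected range from 1.5 nM to 400 nM in this assay.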

Compound 4, half-maximal inhibitory concentration: 6.4 nM
Compound 4: middle estimate off by 2.3-fold (0.37 log units), on the high side, within the range that was stated.
By their numbers in this assay, from the lowest: compound 2; then compound 4; then compounds 3 and 1 (each within the scatter of the next).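

In this assay, putting 5-fluoro-2-methylphenyl in place of 3-bromophenyl on the amide-type nitrogen gives a 3.8-fold higher number from compound 2 to compound 4 (0.58 log units; beyond the scatter), a modest step but one that lies beyond the scatter of repeated measurements. Among the compounds shown here, this is the first measured change at this place made on the rest of the structure of compound 2, whereas the only earlier step here, a 2.0-fold lower number from compound 1 to compound 3 (0.30 log units; within the scatter), was made on a different remainder of the molecule and stayed within the scatter. Compound 4 still gives 6.4 nM, so in this pair a very low number does not depend on keeping the 3-bromophenyl group, and an aromatic ring carrying fluorine and methyl instead of bromine also reaches it.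

No measurement available here accounts for the size of this step. Open questions are whether the rise follows the loss of bromine or the arrival of fluorine and methyl, which come together in this one swap, and whether a group of another kind at this place, such as an amine, a carboxylic acid or a longer chain, would keep the number this low.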